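The source may hold more compounds than are shown below. What is called first, only, known or untested is meant among the compounds shown, and "the series" means these compounds.

Working notes on the series. Compound 1 `Fc1cncc(-c2nc3cc(F)c(Cl)cc3n2C2CC2)c1` and compound 2 `CS(=O)(=O)c1ccc2c(c1)nc(-c1cccnc1)n2C1CC1` share a core and are measured in an assay on V79 cells for inhibition of cytochrome P450 11B2, mitochondrial (Homo sapiens), read by HTRF, with a stated time of 1 h; a lower number here means a stronger inhibitor, a higher number a weaker inhibitor. In this assay compound 1 gives 0.8 nM. For compound 2 this assay reports only a limit, > 1000 nM, so no number is known for it; it sits at the limit of > 1000 nM in this assay, at which 1 of the 2 values shown sits. Among the compounds with values here, the two values shown differ widely, but no step is computed between them, as the two compounds differ in more than one place.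

Compound 3 `Fc1ccc2c(c1)nc(-c1cccnc1)n2C1CC1` is not yet measured. It differs from compound 2 by fluoro in place of methylsulfonyl on an aromatic carbon. With compound 2 known only as a limit, the size of the step cannot be read off; the expectation is a gain in potency beyond the usual scatter, of the order of an at least 33-fold lower number from compound 2 to compound 3 (1.52 log units; beyond the scatter). Compound 3 is estimated at 30 nM in this assay, with a range from 3 nM to 300 nM.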

Compound 3, half-maximal inhibitory concentration: 28 nM
Estimate against measurement, compound 3: 1.1-fold (0.03 log units) above; low and high end bracket the measured number.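

Fluoro in place of methylsulfonyl on this aromatic carbon gives an at least 35-fold lower number from compound 2 to compound 3 (1.55 log units; beyond the scatter) in this assay. Within the data shown here, this is the first comparison that differs in one place, and it shows that the group on this carbon alone can move the read-out well beyond the scatter. The value of compound 2 is a limit, and the true size of the step stays unknown: the limit of > 1000 nM in this assay, at which 1 of the 3 values shown sits.

On these data alone, whether the gain belongs to fluoro itself or to the departure of methylsulfonyl stays open; a hydrogen, a methoxy group or an amine on this carbon would separate the two. Among these compounds, no single-place step yet links compound 1 to compound 2 or compound 3, so what each of its differences contributes also stays open.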